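A few compounds are considered here, and "the series" means these few. Any claim that something is new, unique, unknown or untested is made for them only; others in the source may bear on it.

Of the compounds shown here, three sharing one core have been measured in a functional assay on K562 cells (Homo sapiens) for antiproliferative activity, read by MTT assay, with a stated time of 48 h; a lower number here means a stronger inhibitor, a higher number a weaker inhibitor. Compound 1 `COc1ccc(-c2ccc3c(c2)C(=O)C(=O)N3Cc2ccc(C)cc2)cc1` gives 270 nM. Compound 2 `COc1ccc(CN2C(=O)C(=O)c3cc(-c4ccc(OC)cc4)ccc32)cc1` gives 30 nM. Compound 3 `COc1ccc(-c2ccc3c(c2)C(=O)C(=O)N3Cc2ccc(C#N)cc2)cc1` gives 380 nM, the highest number of the three: one of its steps, a 1.4-fold higher number from compound 1 to compound 3 (0.15 log units; within the scatter), stays within the scatter, while the other, a 13-fold higher number from compound 2 to compound 3 (1.10 log units; beyond the scatter), lies clearly beyond it.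

Compound 4 `COc1ccc(-c2ccc3c(c2)C(=O)C(=O)N3Cc2ccc3ccccc3c2)cc1` differs from compound 3 in one place: naphthalen-2-yl in place of 4-cyanophenyl on a saturated chain carbon bound to an amide-type nitrogen in a ring. The steps measured so far all swap one small substituent for another at this same position. Two of them involve the cyano group that leaves here, namely a 1.4-fold higher number from compound 1 to compound 3 (0.15 log units; within the scatter) and a 13-fold higher number from compound 2 to compound 3 (1.10 log units; beyond the scatter), and the third, a 9.0-fold lower number from compound 1 to compound 2 (0.95 log units; beyond the scatter), shows that this position can shift the number by a modest amount. None of them brings in a second fused ring, so they give only a loose guide. Because compound 1 gives 270 nM and compound 3 gives 380 nM, two numbers within the scatter of each other, a change that removes the cyano group is expected to move the number little, and compound 4 is estimated at 300 nM, within a range from 80 nM to 1200 nM, which means an expected step of a 1.3-fold lower number from compound 3 to compound 4 (0.10 log units; within the scatter).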

Compound 4, half-maximal inhibitory concentration: 400 nM
Compound 4: the middle estimate sits 1.3-fold (0.12 log units) below what was measured, and the stated range covers the measured number.
By their numbers in this assay, from the lowest: compound 2; then compounds 1, 3 and 4 (each within the scatter of the next).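

In this assay, the step of a 1.1-fold higher number from compound 3 to compound 4 (0.02 log units; within the scatter) and the step of a 1.5-fold higher number from compound 1 to compound 4 (0.17 log units; within the scatter) both stay within the scatter, so on a saturated chain carbon bound to an amide-type nitrogen in a ring, naphthalen-2-yl, with its second fused ring, reads the same as 4-cyanophenyl or 4-methylphenyl. The same exchange for 4-methoxyphenyl gives a 13-fold higher number from compound 2 to compound 4 (1.12 log units; beyond the scatter), so a second aromatic ring does not reproduce what 4-methoxyphenyl gives, and compound 2 remains the only one of the four set apart from the rest by more than the scatter. No measurement offered here explains why this one group stands apart.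

The compounds shown leave open how specific the effect is to the methoxy group, a question that 4-ethoxyphenyl, 4-hydroxyphenyl or 4-aminophenyl at this place would address. They also leave open whether an aromatic ring is needed here at all, which a saturated cyclohexyl ring, or a naphthalen-2-yl carrying its own methoxy group, could help to answer.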